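A Phenyl Substituent and Permeability Across Four Analogues

The compounds below may be only part of what the source reports. "The series", "measured", "known", "first", "only" and "open" are said of these compounds alone.

Within the data shown here, compound 1 `N#Cc1cc(C#N)c(NCCCCC2CCN(Cc3ccccc3)CC2)nc1N` was tested in an ADME assay for permeability, using PAMPA, in phosphate buffer, with a stated time of 4 h, tested at 1 mg/mL (on this read-out higher numbers stand for higher permeability and lower numbers for lower permeability), and gave 21.2 10^-6 cm/s, the second highest of the three numbers measured so far. Compound 3 `N#Cc1cc(C#N)c(NCCCC2CCN(Cc3ccccc3)CC2)nc1N` gave 20.8 10^-6 cm/s, which lies within the scatter of the number for compound 1. Compound 2 `N#Cc1c(N)nc(NCCC2CCN(Cc3ccccc3)CC2)c(C#N)c1-c1ccccc1` gave 34 10^-6 cm/s, and this gap from compound 1 is also within the scatter. Compound 4 `N#Cc1c(N)nc(NCCCCC2CCN(Cc3ccccc3)CC2)c(C#N)c1-c1ccccc1` has not been measured. It differs from compound 1 by phenyl in place of hydrogen on an aromatic carbon. Among the measured compounds shown here, no measured pair shows this change alone, so the size of the step is uncertain; the numbers for compound 2 point to nothing beyond the scatter. Compound 4 is expected to give 28 10^-6 cm/s, with a range from 17 10^-6 cm/s to 45 10^-6 cm/s. The step of a 1.3-fold higher number from compound 1 to compound 4 (0.12 log units; within the scatter) is expected to be small and upward.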

Compound 4, apparent permeability: 25.7 10^-6 cm/s
Estimate against measurement, compound 4: 1.1-fold (0.04 log units) above; measured number inside the range.
By their numbers in this assay, from the lowest: compounds 3, 1, 4 and 2 (each within the scatter of the next).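

Among these compounds, compound 4 gives the first direct reading of phenyl in place of hydrogen on this aromatic carbon, ortho to two cyano groups and opposite the ring nitrogen. The step of a 1.2-fold higher number from compound 1 to compound 4 (0.08 log units; within the scatter) in this assay shows that this position takes the six extra heavy atoms of phenyl with no change beyond the scatter, though this is a single pair. Nothing measured here offers an explanation for this result.

From the compounds shown here alone, whether an amine or a carboxylic acid on this carbon would also stay within the scatter of compound 1 remains open. So does whether phenyl would give a similar step on a longer chain.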